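J774 cytotoxicity notes: methyl for hydrogen at two ether oxygens

The source may report more compounds than this note shows. Statements on the series, on what has been measured and on what is new or still open speak of the compounds shown alone.

Measured compounds:
compound 1, `CCCCc1cc2c(=O)c(C(=O)OCC)c[nH]c2cc1OCCOc1ccccc1`, > 20000 nM
compound 2, `CCCCc1cc2c(=O)c(C(=O)OC)c[nH]c2cc1OCCOc1ccccc1`, > 20000 nM
compound 3, `COC(=O)c1c[nH]c2ccc(OC)cc2c1=O`, 6180 nM

In an ADME assay on J774 cells (Mus musculus) for cytotoxicity (a lower number here means that less compound is needed, a higher number that more compound is needed for the effect), compound 1 gives > 20000 nM, which is a limit of the assay and not a number. Compound 2 likewise gives > 20000 nM, again a limit. Among the measured compounds shown here, compound 3 gives 6180 nM, the only number among the three values.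

Compound 1 and compound 2 differ by methyl in place of hydrogen on a saturated chain carbon bound to an oxygen next to a carbonyl group. The step that the two limits leave unreadable from compound 2 to compound 1 cannot be sized, since both values sit at the limit of > 20000 nM in this assay, at which 2 of the 3 values shown sit.

Compound 3 and compound 2 share no single-point difference; how the two cores differ is not broken down here.

Compound 4, `CCOc1ccc2[nH]cc(C(=O)OC)c(=O)c2c1`, has not yet been measured. It differs from compound 3 by methyl in place of hydrogen on a saturated chain carbon bound to an oxygen on an aromatic ring. This is the same kind of change as from compound 2 to compound 1, but not the same: there the place is a saturated chain carbon bound to an oxygen next to a carbonyl group, here it is a saturated chain carbon bound to an oxygen on an aromatic ring.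

The measured step gives no usable size for the change, so the expectation for compound 4 rests only on compound 3 and its value 6180 nM, with the step expected to stay within scatter at a 1.1-fold higher number from compound 3 to compound 4 (0.02 log units; within the scatter). Compound 4 is expected to give about 6500 nM in this assay, most likely between 2500 nM and 17000 nM.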

Compound 4, half-maximal effective concentration: > 20000 nM
Compound 4 was reported as a limit (the forecaster's own chance of this, stated with the estimate: 15%); at least 3.0-fold (0.48 log units) between middle value and limit.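

In this assay, methyl in place of hydrogen on a saturated chain carbon bound to an oxygen on an aromatic ring, the change of methoxy to ethoxy, gives an at least 3.2-fold higher number from compound 3 to compound 4 (0.51 log units; beyond the scatter), so on the core of compound 3 this small change moves the result beyond the usual scatter. Compound 4 gives > 20000 nM, which is a limit of the assay and not a number. The same kind of change on the other core, at a saturated chain carbon bound to an oxygen next to a carbonyl group, cannot be read between compound 2 and compound 1, so the series offers no second size to set against this one and no test of whether the step carries from one core to another, with most of the values resting on a single limit: the limit of > 20000 nM in this assay, at which 3 of the 4 values shown sit.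

The compounds shown leave open how the result runs further along this chain, with a longer chain such as propoxy, or with an amine or a carboxylic acid at the end of it, on the core of compound 3. Also open, as far as these compounds go, is how the change at the ester oxygen reads on that core, where compound 3 gives 6180 nM, a number rather than a limit.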